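Cyclohexyl to ethyl on the oxygen: compound 3 to compound 4

The source may report more compounds than this note shows. Statements on the series, on what has been measured and on what is new or still open speak of the compounds shown alone.

The series varies the group on an oxygen on a saturated carbon attached to the shared core. In a functional assay on PC-3 cells (Homo sapiens) for cytotoxicity, read by MTT assay, with a stated time of 72 h (a higher number here means a weaker inhibitor, a lower number a stronger inhibitor), compound 1 `[O-][n+]1nc(NCOCc2ccc(Cl)cc2)[n+]([O-])c2ccccc21` gives 5760 nM, compound 2 `CCCCOCNc1n[n+]([O-])c2ccccc2[n+]1[O-]` gives 14700 nM, and compound 3 `[O-][n+]1nc(NCOC2CCCCC2)[n+]([O-])c2ccccc21` gives 3250 nM, the lowest of the three; its nearest neighbour lies within the scatter, while a 4.5-fold lower number from compound 2 to compound 3 (0.66 log units; beyond the scatter) marks the one gap beyond it. Compound 4 `CCOCNc1n[n+]([O-])c2ccccc2[n+]1[O-]` differs from compound 3 by ethyl in place of cyclohexyl on an oxygen on a saturated carbon. The step that bears on this is a 4.5-fold lower number from compound 2 to compound 3 (0.66 log units; beyond the scatter), where a butyl chain gave way to the ring; the present change runs the other way, to a chain shorter than butyl, and a 2.6-fold higher number from compound 1 to compound 2 (0.41 log units; beyond the scatter) adds little. A higher number is therefore expected for compound 4, estimated at 18000 nM with a range of 7000 nM to 45000 nM. The expected step from compound 3 to compound 4 is a 5.5-fold higher number from compound 3 to compound 4 (0.74 log units; beyond the scatter).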

Compound 4, half-maximal inhibitory concentration: 15900 nM
Estimate against measurement, compound 4: 1.1-fold (0.05 log units) above, within the range that was stated.
By their numbers in this assay, from the lowest: compounds 3 and 1 (each within the scatter of the next); then compounds 2 and 4 (each within the scatter of the next).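

In this assay, a 4.9-fold higher number from compound 3 to compound 4 (0.69 log units; beyond the scatter) shows that the loss on leaving cyclohexyl is not peculiar to butyl, and ethyl sits with the chains rather than the ring. With a 1.1-fold higher number from compound 2 to compound 4 (0.03 log units; within the scatter) in hand, butyl and ethyl stand level, so chain length over this span does not register. The further step, a 2.8-fold higher number from compound 1 to compound 4 (0.44 log units; beyond the scatter) in this series, keeps both chain compounds on the higher side of the two ring-bearing compounds.

On these data alone, whether a cyclopentyl ring or a terminal amine on the chain would keep the lower numbers remains open. Nothing measured on these compounds accounts for the steps.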